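Neopentylpiperazine in place of the hydroxypiperidine on the core

A few compounds are considered here, and "the series" means these few. Any claim that something is new, unique, unknown or untested is made for them only; others in the source may bear on it.

Working notes on a small set measured in a functional assay on CHO-K1 cells for antagonist activity at melanin-concentrating hormone receptor 1 (Homo sapiens), read by inositol phosphate accumulation; a higher number here means a weaker inhibitor, a lower number a stronger inhibitor.

Compound 1 `Cc1nc(N2CCC(O)CC2)nc2ccc(NC(=O)C(C)(C)Oc3ccc(Cl)cc3)cc12` returns only a limit in this assay, > 10000 nM; this is the limit of > 10000 nM in this assay, at which 1 of the 3 values shown sits. Compound 2 `Cc1nc(N2CCC(C)(O)CC2)nc2ccc(NC(=O)COc3ccc(Cl)cc3)cc12` gives 827 nM in this assay, the higher of the two numbers available. Compound 3 `Cc1nc(N2CCN(C(=O)C3CCC3)CC2)nc2ccc(NC(=O)COc3ccc(OC(F)(F)F)cc3)cc12` gives 45 nM in this assay, a gap from compound 2 that lies beyond the scatter.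

Compound 4 `Cc1nc(N2CCN(CC(C)(C)C)CC2)nc2ccc(NC(=O)COc3ccc(Cl)cc3)cc12` is not yet measured. It differs from compound 2 by 4-neopentylpiperazin-1-yl in place of 4-hydroxy-4-methylpiperidin-1-yl on an aromatic carbon. The group entering carries a six-membered non-aromatic ring with 2 hetero atoms and 0 hydrogen-bond donors, a feature compound 3 shares with its value of 45 nM. The step of a 5.5-fold lower number from compound 2 to compound 4 (0.74 log units; beyond the scatter) is expected, toward a lower number. Compound 4 is expected near 150 nM in this assay. The estimated range for compound 4 runs from 40 nM to 600 nM.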

Compound 4, half-maximal inhibitory concentration: 246 nM
Estimate against measurement, compound 4: 1.6-fold (0.21 log units) below; low and high end bracket the measured number.
By their numbers in this assay, from the lowest: compound 3; then compound 4; then compound 2. At a limit, above all of these: compound 1.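

In this assay, for the compounds shown here, 4-neopentylpiperazin-1-yl in place of 4-hydroxy-4-methylpiperidin-1-yl gives a 3.4-fold lower number from compound 2 to compound 4 (0.53 log units; beyond the scatter), the first single-place reading at this position on the core. In this pair, activity at this position does not depend on the hydrogen-bond donor of the leaving group. Nothing shown gives a cause for this step.

From the compounds shown here alone, the change alters the ring and its substituent together, so their separate contributions remain open. A 4-methylpiperazin-1-yl or a morpholine group at this position would help separate them.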